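From Dimethylcarbamoyl to Triazole on the Saturated Ring

The source may report more compounds than this note shows. Statements on the series, on what has been measured and on what is new or still open speak of the compounds shown alone.

In an ADME assay on S9 fraction from liver (Homo sapiens) for metabolic stability, with a stated time of 1 h (on this read-out higher numbers stand for a more stable compound and lower numbers for a less stable compound), compound 1 `N#Cc1cnc(NCc2cnccc2C(F)(F)F)cc1N[C@H]1CC[C@@H](O)CC1` gives 33%, compound 2 `CO[C@H]1CC[C@@H](Nc2cc(NCc3cnccc3C(F)(F)F)ncc2C#N)CC1` gives 19%, and compound 3 `CN(C)C(=O)[C@H]1CC[C@@H](Nc2cc(NCc3cnccc3C(F)(F)F)ncc2C#N)CC1` gives 48%, the highest of the three. Compound 4 `N#Cc1cnc(NCc2cnccc2C(F)(F)F)cc1N[C@H]1CC[C@@H](n2cncn2)CC1` has 1H-1,2,4-triazol-1-yl in place of dimethylcarbamoyl on a saturated ring carbon. The measured changes on this carbon are a number 15 percentage points higher from compound 1 to compound 3 (beyond the scatter), a number 29 percentage points higher from compound 2 to compound 3 (beyond the scatter) and a number 14 percentage points lower from compound 1 to compound 2 (beyond the scatter), all modest. None of them introduces the triazole, so the direction remains uncertain. With compound 3 at the top at 48%, a modest fall in this assay is expected, estimated as a number 11 percentage points lower from compound 3 to compound 4 (beyond the scatter). The estimate for compound 4 is 37%, with an expected range from 18% to 60%.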

Compound 4, percent of the compound remaining: 64%
For compound 4 the middle estimate is 27 percentage points below the measured one, outside the stated range (above it).
By their numbers in this assay, from the lowest: compound 2; then compound 1; then compound 3; then compound 4.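

On this saturated ring carbon, the step of a number 16 percentage points higher from compound 3 to compound 4 (beyond the scatter) shows in this assay that the best group so far can be passed by 1H-1,2,4-triazol-1-yl, which has the same number of heavy atoms as dimethylcarbamoyl. Within the data shown here, the steps of a number 45 percentage points higher from compound 2 to compound 4 (beyond the scatter) and a number 31 percentage points higher from compound 1 to compound 4 (beyond the scatter) are both large, whereas all those among the earlier compounds were modest, so this position has a wider span than they revealed. Nothing available accounts for the gain.

Going by these compounds, whether another five-membered aromatic ring, such as pyrazol-1-yl, would match the triazole here stays open. So does how an amine or a carboxylic acid on this carbon would compare.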